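Replacing 4-bromophenyl by 3,4-dichlorophenyl on the shared core

A few compounds are considered here, and "the series" means these few. Any claim that something is new, unique, unknown or untested is made for them only; others in the source may bear on it.

compound 1 `O=C(NO)c1ccc(NCc2nc(-c3ccc(Br)cc3)nn2-c2ccccc2)cc1`: 54.7%
compound 2 `O=C(NO)c1ccc(NCc2nc(-c3ccccc3)nn2-c2cccc(Cl)c2)cc1`: 62.3%

In an assay on Sf9 cells for inhibition of protein deacetylase HDAC6 (Homo sapiens), read by fluorescence, with a stated time of 40 min, tested at 100 nM (on this read-out higher numbers stand for more inhibition at the one concentration tested (going by the name of the read-out) and lower numbers for less inhibition), compound 1 gives 54.7%, which puts it at the bottom of the two numbers, yet the gap to compound 2 at 62.3% is within the scatter, so the two compounds cannot be told apart. Compound 3 `O=C(NO)c1ccc(NCc2nc(-c3ccc(Cl)c(Cl)c3)nn2-c2ccccc2)cc1` differs from compound 1 by 3,4-dichlorophenyl in place of 4-bromophenyl on an aromatic carbon. Within the data shown here, no measured pair shows this change, so its size is unknown; the step of a number 3.3 percentage points higher from compound 1 to compound 3 (within the scatter) is expected to stay within the scatter, in no clear direction. Compound 3 is therefore estimated at 58%, with a range from 40% to 76%.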

Compound 3, a percentage reported as inhibition, at one concentration (the size of the read-out at that concentration, not a potency): 34.5%
For compound 3 the middle estimate is 23.5 percentage points above the measured one; measured number below the stated range.
By their numbers in this assay, from the lowest: compound 3; then compounds 1 and 2 (each within the scatter of the next).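

Swapping 4-bromophenyl for 3,4-dichlorophenyl on this aromatic carbon of the shared core is not neutral in this assay: it gives a number 20.2 percentage points lower from compound 1 to compound 3 (beyond the scatter) and so separates this pair. Among these compounds, compound 1 and compound 2 differ in more than one place, so this is the first reading of a change at this position alone. Nothing measured here explains the drop.

On these data alone, it remains open whether the second chlorine or the exchange of bromine for chlorine carries the step. 4-chlorophenyl would separate the two, and an amine or a carboxylic acid on that phenyl ring would test non-halogen groups there.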